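The source may report more compounds than this note shows. Statements on the series, on what has been measured and on what is new or still open speak of the compounds shown alone.

Measured compounds:
- compound 1, `Nc1scc(CN2CCN(c3ccc(Cl)cc3F)CC2)c1C(=O)c1ccc(Cl)cc1`: -57%
- compound 2, `Nc1scc(CN2CCN(c3ccccc3C(F)(F)F)CC2)c1C(=O)c1ccc(Cl)cc1`: -39%
- compound 3, `Nc1scc(CN2CCC(c3ccc(Cl)cc3)CC2)c1C(=O)c1ccc(Cl)cc1`: -24%

All three share one core and differ only in the group attached to the saturated ring. In a functional assay on CHO cells with adenosine receptor A1 (Homo sapiens) as the target, read by cAMP accumulation and immunoassay, with a stated time of 6 min, tested at 1 uM (on this read-out higher numbers stand for a weaker effect at the one concentration tested and lower numbers for a stronger effect), compound 2 gives -39%, the second highest of the three numbers: compound 1 gives -57%, and compound 3 gives -24%. Both gaps from compound 2 lie beyond the scatter, so compound 2 sits clearly between the other two.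

Compound 4, `Nc1scc(CN2CCN(c3cccc(F)c3F)CC2)c1C(=O)c1ccc(Cl)cc1`, has not yet been measured. Its change from compound 2 is 2,3-difluorophenyl in place of 2-(trifluoromethyl)phenyl on an amine nitrogen in a ring. Going by the values given here, only one measured step touches the group on the ring nitrogen: a number 18 percentage points higher from compound 1 to compound 2 (beyond the scatter), a modest weakening when 4-chloro-2-fluorophenyl gave way to 2-(trifluoromethyl)phenyl. Compound 4 goes back to a phenyl carrying two halogen atoms, as compound 1 does, though the two groups are not the same. A partial return toward the number of compound 1 is therefore expected. Compound 4 is expected to give -48% in this assay, within -70% to -26%. The expected step is a number 9 percentage points lower from compound 2 to compound 4 (within the scatter), in the strengthening direction.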

Compound 4, a percentage reported as activity, at one concentration (the size of the read-out at that concentration, not a potency): -66%
Compound 4: middle estimate off by 18 percentage points, on the high side; measured number inside the range.
By their numbers in this assay, from the lowest: compounds 4 and 1 (each within the scatter of the next); then compound 2; then compound 3.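

In this assay, the group on the ring nitrogen moves the number beyond the scatter a second time: 2,3-difluorophenyl in place of 2-(trifluoromethyl)phenyl gives a number 27 percentage points lower from compound 2 to compound 4 (beyond the scatter) and so a stronger effect. The two phenyl groups that each carry two halogen atoms cannot be told apart, since 4-chloro-2-fluorophenyl and 2,3-difluorophenyl give a number 9 percentage points lower from compound 1 to compound 4 (within the scatter) and no order can be drawn from them. Among the three compounds with this nitrogen-bearing ring, the one with 2-(trifluoromethyl)phenyl therefore stands apart on the weaker side, while the other two stay together.

Going by these compounds, it remains open how a plain phenyl, or a phenyl carrying a methoxy group or a nitrile, would read at this nitrogen. Nothing in the data shown says why the number moves with these groups.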